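The source may report more compounds than this note shows. Statements on the series, on what has been measured and on what is new or still open speak of the compounds shown alone.

Compound 1 `Cc1ccc(-c2nc3sc(Cc4ccc(Cl)cc4)nn3c2Br)cc1` was tested in a functional assay on HeLa cells (Homo sapiens) for cytotoxicity, with a stated time of 72 h; a lower number here means a stronger inhibitor, a higher number a weaker inhibitor. In this assay compound 1 gives > 250000 nM; this is a limit of the assay, not a number. Compound 2 `Clc1ccc(Cc2nn3c(Br)c(-c4ccc(Cl)cc4Cl)nc3s2)cc1` carries 2,4-dichlorophenyl in place of 4-methylphenyl on an aromatic carbon and in this assay compound 2 gives 118000 nM, a step of an at least 2.1-fold lower number from compound 1 to compound 2 (0.32 log units; beyond the scatter). The size of that step is known only as a bound because of the limit of > 250000 nM in this assay, at which 1 of the 3 values shown sits, the limit at which compound 1 sits. Compound 3 `Cc1ccc(-c2nc3sc(Cc4ccc(Cl)cc4)nn3c2SC#N)cc1` differs from compound 1 by cyanosulfanyl in place of bromo on an aromatic carbon; in this assay compound 3 gives 22000 nM, a step of an at least 11-fold lower number from compound 1 to compound 3 (1.05 log units; beyond the scatter). Compound 4 `N#CSc1c(-c2ccc(Cl)cc2Cl)nc2sc(Cc3ccc(Cl)cc3)nn12` differs from compound 3 by 2,4-dichlorophenyl in place of 4-methylphenyl on an aromatic carbon. This is the same kind of change as between compound 1 and compound 2, not the same: here the place is next to the ring atom that bears a cyanosulfanyl group, there next to the ring atom that bears a bromo group. A step of a 2.2-fold lower number from compound 3 to compound 4 (0.34 log units; beyond the scatter) is expected, resting on an at least 2.1-fold lower number from compound 1 to compound 2 (0.32 log units; beyond the scatter). Compound 4 is therefore estimated at 10000 nM. For compound 4 the expected range runs from 3500 nM to 30000 nM.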

Compound 4, half-maximal inhibitory concentration: 18000 nM
Compound 4: middle estimate off by 1.8-fold (0.26 log units), on the low side; the range from low to high includes it.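

In this assay, the change to 2,4-dichlorophenyl comes to a 1.2-fold lower number from compound 3 to compound 4 (0.09 log units; within the scatter), and the change to cyanosulfanyl comes to a 6.6-fold lower number from compound 2 to compound 4 (0.82 log units; beyond the scatter). The first change can be set against its earlier step only as a bound, so this does not show whether its size carries from one core to the other: the same change on two cores in this assay, an at least 2.1-fold lower number (0.32 log units; beyond the scatter) from compound 1 to compound 2 and a 1.2-fold lower number (0.09 log units; within the scatter) from compound 3 to compound 4; the limit leaves it open whether they differ. The change to cyanosulfanyl lowers the number beyond the scatter on both cores, which shows that its direction carries over in these two pairs but does not settle whether its size does: the same change on two cores in this assay, an at least 11-fold lower number (1.05 log units; beyond the scatter) from compound 1 to compound 3 and a 6.6-fold lower number (0.82 log units; beyond the scatter) from compound 2 to compound 4; the limit leaves it open whether they differ. The compounds shown leave open what an amine or a carboxylic acid would give in place of cyanosulfanyl. They also leave open how either change would behave on a core carrying a longer chain.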